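A few compounds are considered here, and "the series" means these few. Any claim that something is new, unique, unknown or untested is made for them only; others in the source may bear on it.

Measured compounds:
Compound 1, `COc1ccccc1/C=C1\CCC/C(=C\c2cccc(OC)c2OC)C1=O`: in a functional assay on SW-620 cells (Homo sapiens) for cytotoxicity, read by MTT assay, with a stated time of 72 h (a lower number here means a stronger inhibitor, a higher number a weaker inhibitor), compound 1 gives > 20000 nM, which is a limit of the assay rather than a number.
Compound 2, `COc1ccc(/C=C2\CCC/C(=C\c3cccc(OC)c3OC)C2=O)c(OC)c1`: in this assay compound 2 gives > 20000 nM, again a limit of the assay rather than a number.
Compound 3, `COc1cccc(/C=C2\CCC/C(=C\c3ccc(OC)c(OC)c3)C2=O)c1`: in this assay compound 3 gives 3700 nM.

Compound 2 arises from compound 1 by one change, (methoxy in place of hydrogen on an aromatic carbon), but the result is a step that the two limits leave unreadable from compound 1 to compound 2, and this is so because of the limit of > 20000 nM in this assay, at which 2 of the 3 values shown sit. Compound 3 shares its atoms with compound 1 but joins them differently; the difference between the two cores is not broken down here. Compound 3 is the only one of the three with a number rather than a limit.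

The unmeasured compound 4, `COc1cc(/C=C2\CCC/C(=C\c3ccc(OC)c(OC)c3)C2=O)cc(OC)c1`, comes from compound 3 by methoxy in place of hydrogen on an aromatic carbon. Within the data shown here, this is the same kind of change as the one from compound 1 to compound 2, though the place differs: in compound 4 the methoxy enters meta to a large group, whereas in compound 2 it enters para to a large group. Since the earlier step is not readable, it gives no size to borrow, so the expectation leans mainly on compound 3 and its value 3700 nM. Compound 4 is expected to show a step of a 1.5-fold lower number from compound 3 to compound 4 (0.17 log units; within the scatter) in this assay, a small one, with the estimate for compound 4 placed at 2500 nM, expected to fall between 800 nM and 8000 nM.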

Compound 4, half-maximal inhibitory concentration: 2500 nM
Beside the measured number, compound 4's estimate shows no gap at the digits printed; the measured number falls inside the stated range.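

On the core of compound 3, replacing a hydrogen on an aromatic carbon with methoxy, meta to a large group and meta to a methoxy group, gives in this assay a 1.5-fold lower number from compound 3 to compound 4 (0.17 log units; within the scatter), so the two values cannot be told apart and this placement of the group makes no readable difference on this core. The same kind of replacement on the core of compound 1, which leads to compound 2, cannot be read, because both compounds give a limit and not a number: the limit of > 20000 nM in this assay, at which 2 of the 4 values shown sit. The series therefore offers only one readable size for this change, and it does not show whether that result carries from one core to the other, particularly as the methoxy does not enter at the same place in the two pairs.

Among the compounds shown, every substituent on the aromatic rings is a methoxy group, so it remains open how an amine, a carboxylic acid or a longer chain such as ethoxy would read at this place on the ring. On these data alone, it also remains open how the methoxy replacement would read at other places on the ring of compound 3, or on the other aromatic ring.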